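The source may hold more compounds than are shown below. What is called first, only, known or untested is meant among the compounds shown, and "the series" means these compounds.

Measured compounds in a functional assay on HeLa cells (Homo sapiens) for antiproliferative activity, read by MTT assay, with a stated time of 72 h; a lower number here means a stronger inhibitor, a higher number a weaker inhibitor:
compound 1 `COc1ccc2occ(CSC(=S)N(C(C)C)C(C)C)c(=O)c2c1` gives 5400 nM;
compound 2 `Cc1ccc2c(=O)c(CSC(=S)N3CCCC3)coc2c1` gives 4400 nM;
compound 3 `COc1ccc2occ(CSC(=S)N3CCCC3)c(=O)c2c1` gives 12100 nM.

Compound 1 and compound 3 share a core and differ in one place: diisopropylamino in place of pyrrolidin-1-yl on a thiocarbonyl carbon. That change gives a 2.2-fold lower number from compound 3 to compound 1 (0.35 log units; beyond the scatter). Compound 2 carries a different core from compound 3; the difference between the two cores is not broken down here. Compound 2 and compound 1 lie within the scatter of each other, while compound 3 sits beyond the scatter from both.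

Compound 4 `Cc1ccc2c(=O)c(CSC(=S)N(C(C)C)C(C)C)coc2c1` is not yet measured. It stands to compound 2 as compound 1 stands to compound 3: diisopropylamino in place of pyrrolidin-1-yl on a thiocarbonyl carbon. The place is the same in both pairs, so this is the same change. In this assay compound 4 is expected to step a 1.9-fold lower number from compound 2 to compound 4 (0.28 log units; within the scatter), a little short of the earlier step, because a 2.2-fold lower number from compound 3 to compound 1 (0.35 log units; beyond the scatter) is seen once only. The estimate for compound 4 is 2300 nM, between 1100 nM and 5000 nM.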

Compound 4, half-maximal inhibitory concentration: 1400 nM
The estimate for compound 4 lay 1.6-fold (0.22 log units) above the measured number, within the range that was stated.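

In this assay, diisopropylamino in place of pyrrolidin-1-yl on a thiocarbonyl carbon gives a 3.1-fold lower number from compound 2 to compound 4 (0.50 log units; beyond the scatter). The change carries across the two cores, with both steps in the same direction and no difference in size beyond the scatter: the same change on two cores in this assay, a 2.2-fold lower number (0.35 log units; beyond the scatter) from compound 3 to compound 1 and a 3.1-fold lower number (0.50 log units; beyond the scatter) from compound 2 to compound 4, 1.4-fold (0.15 log units) apart, within the scatter of two such steps. This supports transfer between these two cores only; it does not show that the step holds on any other core, and it does not identify what in the diisopropylamino group produces it.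

The compounds shown leave open how other amines on the thiocarbonyl carbon, such as piperidine, morpholine or diethylamine, compare with these two groups. Also open, from the compounds shown here alone, is whether the step persists on a core carrying chloro in place of the methyl or methoxy group.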